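A few compounds are considered here, and "the series" means these few. Any claim that something is new, unique, unknown or untested is made for them only; others in the source may bear on it.

Series notes. Of the compounds shown here, two have numbers so far. Compound 1 `Cc1cccc(C(=O)Nc2ccc3c(c2)CC(NS(C)(=O)=O)C3)c1-c1ccc(Cl)cc1` in an assay on isolated protein for inhibition of microsomal triglyceride transfer protein large subunit (Homo sapiens) (a higher number here means a weaker inhibitor, a lower number a stronger inhibitor), gives 100 nM. Compound 2 `Cc1cccc(C(=O)Nc2ccc3c(c2)CC(NS(=O)(=O)c2cccs2)C3)c1-c1ccc(F)cc1` in this assay gives 50 nM. Compound 2 stands alongside compound 1: the two numbers sit within the usual scatter of each other, and since the two structures differ in more than one place, no single step can be read between them.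

Compound 3 `Cc1cccc(C(=O)Nc2ccc3c(c2)CC(NS(=O)(=O)c2cccs2)C3)c1-c1ccc(Cl)cc1` is not yet measured in this assay. It differs from compound 2 by chloro in place of fluoro on an aromatic carbon. Within the data shown here, no measured pair isolates this change, so nothing here shows its size. Given how close compound 1 and compound 2 sit, the expected step of a 1.1-fold lower number from compound 2 to compound 3 (0.05 log units; within the scatter) is none beyond the scatter. For compound 3 in this assay the estimate is 45 nM, with a range from 20 nM to 110 nM.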

Compound 3, half-maximal inhibitory concentration: 120 nM
Compound 3: the middle estimate sits 2.7-fold (0.43 log units) below what was measured, outside the stated range (above it).
By their numbers in this assay, from the lowest: compounds 2, 1 and 3 (each within the scatter of the next, the first and the last beyond it).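

The change from 4-fluorophenyl to 4-chlorophenyl now has a measured size in this assay: a 2.4-fold higher number from compound 2 to compound 3 (0.38 log units; beyond the scatter), a modest step, so with thiophen-2-yl on the sulfonyl sulfur the halogen on the aromatic carbon para to a large group is not interchangeable. Among these compounds, with 4-chlorophenyl held constant, the sulfonyl group can also be read for the first time: a 1.2-fold higher number from compound 1 to compound 3 (0.08 log units; within the scatter), so thiophen-2-yl in place of methyl on the sulfonyl sulfur shows no change beyond the scatter.

Whether the halogen step carries over when methyl sits on the sulfonyl sulfur remains open, since only one fluoro and chloro pair is shown. As far as these compounds go, how this position responds to groups other than these two halogens, such as bromo, methoxy, nitrile or trifluoromethyl, is also open. No measurement here accounts for the halogen step.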